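The source may report more compounds than this note shows. Statements on the series, on what has been measured and on what is new or still open speak of the compounds shown alone.

Working notes on the series.

Compound 1 `CC(=O)NCc1cccc(Cn2nc(NS(=O)(=O)c3ccc(Cl)s3)c3ccccc32)c1` gives 5.93 in a physicochemical assay for acid dissociation, and stands at the low end of the three numbers, with both other compounds within the scatter of it. Compound 2 `CC(=O)NCc1cccc(Cn2nc(NS(=O)(=O)c3ccc(Cl)s3)c3c(Cl)cccc32)c1` gives 6.03 in this assay, and compound 3 `CC(=O)NCc1cccc(Cn2nc(NS(=O)(=O)c3ccc(Cl)s3)c3c(O)cccc32)c1` gives 6.12. The steps of a number 0.10 log units higher from compound 1 to compound 2 (within the scatter) and a number 0.19 log units higher from compound 1 to compound 3 (within the scatter) show that neither a chloro nor a hydroxy on that aromatic carbon moves the number beyond the scatter; the step of a number 0.09 log units higher from compound 2 to compound 3 (within the scatter) is likewise within it.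

Compound 4 `CC(=O)NCc1cccc(Cn2nc(NS(=O)(=O)c3ccc(Cl)s3)c3c(C#N)cccc32)c1` differs from compound 1 in one place: cyano in place of hydrogen on an aromatic carbon. Among the compounds with values here, the steps that bear on this change are those from compound 1 to its two substituted analogues, both within the scatter, and the hydroxy and chloro in those steps lie on the same aromatic carbon as the cyano here. No step beyond the scatter is therefore expected in this assay for compound 4, and an estimated shift of a number 0.12 log units higher from compound 1 to compound 4 (within the scatter) is assumed because a number 0.10 log units higher from compound 1 to compound 2 (within the scatter) and a number 0.19 log units higher from compound 1 to compound 3 (within the scatter) were both small. Compound 4 is thus expected to give about 6.05, between 5.65 and 6.45.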

Compound 4, acid dissociation constant: 5.4
Beside the measured number, compound 4's estimate is 0.65 log units above it; measured number outside the range, below it.
By their numbers in this assay, from the lowest: compound 4; then compounds 1, 2 and 3 (each within the scatter of the next).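

Cyano in place of hydrogen gives a number 0.53 log units lower from compound 1 to compound 4 (beyond the scatter) in this assay and is the only change from compound 1 on this aromatic carbon to lie beyond the scatter, so the number is not insensitive to what stands there. Cyano in place of hydroxy gives a number 0.72 log units lower from compound 3 to compound 4 (beyond the scatter) and cyano in place of chloro gives a number 0.63 log units lower from compound 2 to compound 4 (beyond the scatter) on the same carbon, which sets compound 4 apart from each of the other three compounds. No measurement at hand accounts for this separation.

On these data alone, whether another group on this carbon, such as an amine, a carboxylic acid or trifluoromethyl, would also move the number beyond the scatter stays open. Also open, as far as these compounds go, is whether cyano on another carbon of the same six-membered aromatic ring gives a step of similar size.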